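Thiophene in place of hydroxyphenyl on a fused core

This account rests on a few compounds, and the source may have more. Where it says the series, first, only, none or still open, it means among the compounds named here.

Measured so far in a functional assay on Ehrlich cells (Mus musculus) for antiproliferative activity, read by trypan blue exclusion, with a stated time of 2 h, tested at 100 ug/mL; a higher number here means a stronger effect of the compound at the concentration tested, a lower number a weaker effect:
- compound 1 `N#CC1=C(N)N(c2ccc(S(N)(=O)=O)cc2)C2=C(C(=O)CCC2)C1c1ccccc1` gives 40%
- compound 2 `N#CC1=C(N)N(c2ccc(S(N)(=O)=O)cc2)C2=C(C(=O)CCC2)C1c1ccc(O)cc1` gives 100%
- compound 3 `Cc1ccoc1C1C(C#N)=C(N)N(c2ccc(S(N)(=O)=O)cc2)C2=C1C(=O)CCC2` gives 45%

Compound 2 stands highest of the three numbers in this assay; the nearest is compound 3, which lies a number 55 percentage points lower from compound 2 to compound 3 (beyond the scatter), and the furthest is compound 1, which lies a number 60 percentage points higher from compound 1 to compound 2 (beyond the scatter) in the other direction. Compound 1 and compound 3 sit close together, a number 5 percentage points higher from compound 1 to compound 3 (within the scatter).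

Compound 4 `N#CC1=C(N)N(c2ccc(S(N)(=O)=O)cc2)C2=C(C(=O)CCC2)C1c1cccs1` is not yet measured. It differs from compound 2 in one place: thiophen-2-yl in place of 4-hydroxyphenyl on a saturated ring carbon.

Going by the values given here, two measured steps bear on this change. The step from compound 2 to compound 3 also removed the 4-hydroxyphenyl for a five-membered heteroaryl and was a number 55 percentage points lower from compound 2 to compound 3 (beyond the scatter). The step from compound 1 to compound 2 shows what the hydroxy alone brought, a number 60 percentage points higher from compound 1 to compound 2 (beyond the scatter). Both point the same way: losing the 4-hydroxyphenyl has so far cost much of the activity of compound 2. A step of the same kind, downward and beyond the scatter, is therefore expected from compound 2 to compound 4, about a number 55 percentage points lower from compound 2 to compound 4 (beyond the scatter).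

Compound 4 is estimated at 45% in this assay, with a range from 25% to 70%.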

Compound 4, a percentage reported as activity, at one concentration (the size of the read-out at that concentration, not a potency): 100%
Compound 4: middle estimate off by 55 percentage points, on the low side, outside the stated range (above it).
By their numbers in this assay, from the lowest: compounds 1 and 3 (each within the scatter of the next); then compounds 2 and 4 (each within the scatter of the next).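

In this assay, going by these compounds alone, the position on the saturated ring carbon does not depend on the 4-hydroxyphenyl group for a high read-out: with thiophen-2-yl in its place there is no change at the digits printed from compound 2 to compound 4 (within the scatter), so a hydroxy-bearing ring is not the only group that reaches this level. A five-membered aromatic ring at this position is also no single case, as the result shows a number 55 percentage points higher from compound 3 to compound 4 (beyond the scatter), and thiophen-2-yl stands well apart from the plain phenyl group, with a number 60 percentage points higher from compound 1 to compound 4 (beyond the scatter). Nothing measured here accounts for the wide gap between these groups on the shared core.

As far as these compounds go, compound 3 and compound 4 differ in both the ring hetero atom and the methyl group, so it remains open which of the two goes with the large step; an unsubstituted furan-2-yl or a 3-methylthiophen-2-yl group would separate them. Also open, from the compounds shown here alone, is how thiophen-3-yl or 4-aminophenyl would read at this position, and a read-out at a single concentration gives no potency by which compound 2 and compound 4 could be told apart.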